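Same exchange at another site: expected cytotoxicity of compound 3

A few compounds are considered here, and "the series" means these few. Any claim that something is new, unique, unknown or untested is made for them only; others in the source may bear on it.

Compound 1 `c1ccc2[nH]c(-c3ccc(-c4cc5cc(-c6nc7ccccc7[nH]6)ccc5o4)cc3)nc2c1` gives 6700 nM
Compound 2 `c1ccc2[nH]c(-c3ccc4oc(-c5ccc(C6=NCCN6)cc5)cc4c3)nc2c1` gives 6100 nM

In an ADME assay on L6 cells (Rattus norvegicus) for cytotoxicity (a higher number here means a weaker inhibitor, a lower number a stronger inhibitor), compound 1 has only compound 2 for comparison, and the two lie within the scatter of each other. The change leading to compound 3 `c1ccc2[nH]c(-c3ccc(-c4cc5cc(C6=NCCN6)ccc5o4)cc3)nc2c1` is a group of 5 heavy atoms (3 carbon, 2 nitrogen; one five-membered non-aromatic ring with 2 hetero atoms) in place of a group of 9 heavy atoms (7 carbon, 2 nitrogen; one five-membered aromatic ring with 2 hetero atoms, one six-membered aromatic ring of carbon only), on an aromatic carbon and it falls at a different place on the core than in compound 2. Within the data shown here, the one measured step with this exchange is a 1.1-fold lower number from compound 1 to compound 2 (0.04 log units; within the scatter) and it stays within the scatter. From the compounds shown here alone, one step is thin evidence, and the new site is untested. The expected step is a 1.1-fold lower number from compound 1 to compound 3 (0.05 log units; within the scatter) and nothing beyond the scatter is expected. For compound 3 the estimate is 6000 nM with an expected range of 2500 nM to 15000 nM in this assay.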

Compound 3, half-maximal inhibitory concentration: 59300 nM
Beside the measured number, compound 3's estimate is 9.9-fold (0.99 log units) below it; the whole stated range lies below it.
By their numbers in this assay, from the lowest: compounds 2 and 1 (each within the scatter of the next); then compound 3.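

In this assay, replacing the 1H-benzimidazol-2-yl group with the five-membered non-aromatic ring gives an 8.9-fold higher number from compound 1 to compound 3 (0.95 log units; beyond the scatter) at this position, while the same exchange at the other site gave a 1.1-fold lower number from compound 1 to compound 2 (0.04 log units; within the scatter) on the same shared core. The effect of this exchange therefore depends on where it is made, at least in these two cases. Nothing available here explains the difference between the two sites. From the compounds shown here alone, whether another group at this position, such as an amine or a carboxylic acid, would give a similarly high number remains open.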